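This account rests on a few compounds, and the source may have more. Where it says the series, first, only, none or still open, it means among the compounds named here.

Compound 1 `CC(C)C(=O)Nc1c(C(O)(C(F)(F)F)C(F)(F)F)ccc2ccccc12` gives 6630 nM in an assay on LtK cells with ATP-sensitive inward rectifier potassium channel 11 (Homo sapiens) as the target; a lower number here means that less compound is needed, a higher number that more compound is needed for the effect.
Compound 2 `O=C(CCc1ccccc1)Nc1c(C(O)(C(F)(F)F)C(F)(F)F)ccc2ccccc12` gives 1750 nM in this assay.

Among the compounds with values here, of the two numbers measured so far, compound 2 has the lower one, and its only neighbour is compound 1: the step of a 3.8-fold lower number from compound 1 to compound 2 (0.58 log units; beyond the scatter) lies beyond the scatter, so compound 2 needs clearly less compound for the effect than compound 1.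

Compound 3 `O=C(Nc1c(C(O)(C(F)(F)F)C(F)(F)F)ccc2ccccc12)c1cccc(C(F)(F)F)c1` has not yet been measured. It differs from compound 2 at the same carbonyl carbon that was changed before: 3-(trifluoromethyl)phenyl in place of phenethyl on a carbonyl carbon

Within the data shown here, only one measured step bears on this place, a 3.8-fold lower number from compound 1 to compound 2 (0.58 log units; beyond the scatter), and it was modest. Among the measured compounds shown here, it tells that the group on this carbonyl carbon matters, but it does not tell how a 3-(trifluoromethyl)phenyl group compares with a phenethyl group, since no measured pair shows that exchange. The expectation is therefore a step of uncertain direction that need not go beyond the scatter, a 1.4-fold higher number from compound 2 to compound 3 (0.15 log units; within the scatter). Compound 3 is estimated at 2500 nM in this assay, with a range from 700 nM to 9000 nM.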

Compound 3, half-maximal effective concentration: 84 nM
The estimate for compound 3 lay 30-fold (1.47 log units) above the measured number, outside the stated range (below it).
By their numbers in this assay, from the lowest: compound 3; then compound 2; then compound 1.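

In this assay, this carbonyl carbon turns out to be far more sensitive than the first step suggested: the earlier change gave only a 3.8-fold lower number from compound 1 to compound 2 (0.58 log units; beyond the scatter), whereas 3-(trifluoromethyl)phenyl in place of phenethyl gives a 21-fold lower number from compound 2 to compound 3 (1.32 log units; beyond the scatter). Measured against the isopropyl group, the same 3-(trifluoromethyl)phenyl group gives a 79-fold lower number from compound 1 to compound 3 (1.90 log units; beyond the scatter), so the group on the carbonyl carbon can shift the number by a large amount while the rest of the molecule stays the same. Phenethyl and 3-(trifluoromethyl)phenyl each contain one six-membered aromatic ring of carbon only, so the presence of such a ring does not by itself separate compound 2 from compound 3, and nothing available explains the difference between them.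

The compounds shown cannot separate the contribution of the trifluoromethyl group from that of replacing phenethyl with a ring-based group lacking its chain, since a plain phenyl group is not among them. On these data alone, it also remains open whether another group on the ring, such as a chlorine atom or a nitrile, would give a similarly low number.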